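This account rests on a few compounds, and the source may have more. Where it says the series, first, only, none or still open, it means among the compounds named here.

In a functional assay on QGY-7703 cells (Homo sapiens) for cytotoxicity, read by MTT assay, with a stated time of 24 h (on this read-out higher numbers stand for weaker inhibition and lower numbers for stronger inhibition), compound 3 (`O=C1/C(=C/c2ccncc2)CNC/C1=C\c1ccccc1C(F)(F)F`) gives 4900 nM, within the scatter of the two other measured compounds, compound 1 (`CN1C/C(=C\c2ccncc2)C(=O)/C(=C/c2ccccc2C(F)(F)F)C1`) at 4500 nM and compound 2 (`O=C1/C(=C/c2ccncc2)CN(S(=O)(=O)c2ccccc2)C/C1=C\c1ccccc1F`) at 8400 nM. Compound 4 (`O=C1/C(=C/c2ccncc2)CN(S(=O)(=O)c2ccccc2)C/C1=C\c1ccccc1C(F)(F)F`) has phenylsulfonyl in place of hydrogen on an amine nitrogen in a ring. For the measured compounds named here, the only measured step at that nitrogen is a 1.1-fold higher number from compound 1 to compound 3 (0.04 log units; within the scatter), and it involves methyl, not phenylsulfonyl. Going by the values given here, compound 2 also carries phenylsulfonyl there, but no measured step isolates that group. No shift beyond the scatter is therefore expected in this assay, and the estimated step is a 1.2-fold higher number from compound 3 to compound 4 (0.09 log units; within the scatter). Compound 4 is expected at 6000 nM, with an estimated range of 2800 nM to 12000 nM.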

Compound 4, half-maximal inhibitory concentration: 6210 nM
Estimate against measurement, compound 4: 1.0-fold (0.01 log units) below; measured number inside the range.
By their numbers in this assay, from the lowest: compounds 1, 3, 4 and 2 (each within the scatter of the next).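

In this assay, three groups have now been read on the amine nitrogen in the ring, and neither phenylsulfonyl in place of hydrogen (a 1.3-fold higher number from compound 3 to compound 4 (0.10 log units; within the scatter)) nor phenylsulfonyl in place of methyl (a 1.4-fold higher number from compound 1 to compound 4 (0.14 log units; within the scatter)) moves the number beyond the scatter. With phenylsulfonyl on that nitrogen, trifluoromethyl in place of fluoro on an aromatic carbon also stays within the scatter (a 1.4-fold lower number from compound 2 to compound 4 (0.13 log units; within the scatter)). Nothing available explains these small steps. The compounds shown leave open whether a benzyl or acetyl group on that nitrogen would give a step beyond the scatter. The same question stands for chloro or methoxy in place of fluoro on that aromatic carbon.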